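The source may report more compounds than this note shows. Statements on the series, on what has been measured and on what is new or still open speak of the compounds shown alone.

The series shares one core, seen in compound 1 `COc1ccccc1C#Cc1nc2c(s1)C(=O)NCC2`, compound 2 `Fc1cccc(C#Cc2nc3c(s2)CN(C2CCC2)CC3)c1` and compound 3 `O=C(C1CC(F)C1)N1CCc2nc(C#Cc3ccccc3)sc2C1`, and is followed in an assay on HEK293 cells for negative allosteric modulation of metabotropic glutamate receptor 5 (Homo sapiens), read by FLIPR, with a stated time of 1 h; a lower number here means a stronger inhibitor, a higher number a weaker inhibitor. Compound 1 gives only a limit there, > 10000 nM. Compound 2 gives 200 nM in this assay. Compound 3 likewise gives only a limit, > 10000 nM. Compound 3 therefore stands at the weak end of what is shown, sharing its position with compound 1; of the three values given, two sit at that limit, as recorded in the limit of > 10000 nM in this assay, at which 2 of the 3 values shown sit. Compound 4 `O=C(N1CCCC1)N1CCc2nc(C#Cc3ccccc3)sc2C1` differs from compound 3 in one place: pyrrolidin-1-yl in place of 3-fluorocyclobutyl on a carbonyl carbon. Among the compounds with values here, no step between two measured compounds covers this change, so the expectation rests on where compound 3 stands. Compound 4 is expected to remain at or near that limit. The expected step of a number no higher from compound 3 to compound 4 (the limit leaves the size open) would not go beyond the usual scatter. In this assay the estimate for compound 4 is 10000 nM, with a range from 3000 nM to 30000 nM.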

Compound 4, half-maximal inhibitory concentration: > 10000 nM
Compound 4 gave a limit, no number; the forecaster's own chance of this, stated with the estimate: 70%; the middle value lies on the limit itself.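

In this assay, within the data shown here, compound 4 gives only a limit, as compound 3 does, so no step between the two can be read. The compounds shown leave open whether pyrrolidin-1-yl and 3-fluorocyclobutyl on the carbonyl carbon differ at all in inhibition.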